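Swapping halogen for methoxy on a weakly cytotoxic nucleoside

The source may report more compounds than this note shows. Statements on the series, on what has been measured and on what is new or still open speak of the compounds shown alone.

Compound 1 `OC[C@H]1O[C@@H](n2cnc3c(NCc4cccc(F)c4)ncnc32)[C@H](O)[C@@H]1O`: 84000 nM
Compound 2 `OC[C@H]1O[C@@H](n2cnc3c(NCc4cccc(Br)c4)ncnc32)[C@H](O)[C@@H]1O`: > 166000 nM

In an ADME assay on NIH3T3 cells (Mus musculus) for cytotoxicity, with a stated time of 72 h (on this read-out higher numbers stand for weaker inhibition and lower numbers for stronger inhibition), compound 1 gives 84000 nM. Compound 2 reaches only a limit of the assay, > 166000 nM, so its standing is a floor rather than a number. Among the measured compounds shown here, the one measured step, an at least 1.9-fold higher number from compound 1 to compound 2 (0.29 log units; that floor lies within the scatter), is therefore itself only a floor, as the limit of > 166000 nM in this assay, at which 1 of the 2 values shown sits, shows. Compound 3 `COc1cccc(CNc2ncnc3c2ncn3[C@@H]2O[C@H](CO)[C@@H](O)[C@H]2O)c1` differs from compound 2 by methoxy in place of bromo on an aromatic carbon. For the measured compounds named here, no measured step bears directly on this change, so no direction beyond the scatter is expected: compound 3 is estimated at 120000 nM, between 50000 nM and 300000 nM, a step of an at least 1.3-fold lower number from compound 2 to compound 3 (0.14 log units; that floor lies within the scatter).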

Compound 3, half-maximal inhibitory concentration: > 166000 nM
Compound 3: only a limit was reported (the forecaster's own chance of this, stated with the estimate: 45%); at least 1.3-fold (0.14 log units) between middle value and limit.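

Compound 3, with its 3-methoxybenzyl group, also ends at a limit in this assay, not at a number, so a non-halogen group at this place gives the same kind of result as bromo. The change from fluoro to methoxy gives an at least 1.9-fold higher number from compound 1 to compound 3 (0.29 log units; that floor lies within the scatter), so even this floor does not separate the two compounds. The step between compound 2 and compound 3 cannot be read: the limit of > 166000 nM in this assay, at which 2 of the 3 values shown sit.

From the compounds shown here alone, whether an amine or a carboxylic acid at this place would give a lower number stays open. Going by these compounds, how far compound 2 and compound 3 lie past their limits also stays open.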